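Expected lipophilicity of compound 4 from a pyridazine swap

The source may report more compounds than this note shows. Statements on the series, on what has been measured and on what is new or still open speak of the compounds shown alone.

Compound 3 `C[C@@H](Oc1cc2oc(=O)n(CCC(=O)O)c2cc1Cl)c1cccnn1` stands lowest of the three measured compounds: in a physicochemical assay for lipophilicity, read by HPLC, at pH 7.4 (a lower number here means a more polar compound, a higher number a more lipophilic compound), compound 3 gives 0.83. Its nearest neighbour is compound 2 `CCOc1cc2oc(=O)n(CCC(=O)O)c2cc1Cl`, which in this assay gives 1.49, and the step of a number 0.66 log units lower from compound 2 to compound 3 (beyond the scatter) lies beyond the scatter. Furthest away is compound 1 `Cc1ccnc([C@@H](C)Oc2cc3oc(=O)n(CCC(=O)O)c3cc2Cl)c1`, which in this assay gives 2.15; the step of a number 1.32 log units lower from compound 1 to compound 3 (beyond the scatter) is the largest in the set, and a number 0.66 log units lower from compound 1 to compound 2 (beyond the scatter) accounts for the remainder.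

Compound 4 `Cc1cccc([C@@H](C)Oc2cc3oc(=O)n(CCC(=O)O)c3cc2Cl)n1` has not yet been measured. Its structure differs from compound 3 in one place: 6-methylpyridin-2-yl in place of pyridazin-3-yl on a saturated chain carbon bound to an oxygen on an aromatic ring and a saturated chain carbon. The measured step that bears most directly on this change is a number 1.32 log units lower from compound 1 to compound 3 (beyond the scatter): it exchanges a methylpyridin-2-yl group for the same pyridazin-3-yl group at the same place, only in the opposite direction. Compound 4 carries a 6-methylpyridin-2-yl group where compound 1 carries a 4-methylpyridin-2-yl group, so compound 4 is expected to land close to compound 1. An upward step of roughly the size seen from compound 1 to compound 3 is therefore expected, and the estimated step is a number 1.27 log units higher from compound 3 to compound 4 (beyond the scatter). In this assay compound 4 is expected to give about 2.1. The estimate for compound 4 spans 1.7 to 2.5.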

Compound 4, distribution coefficient: 2.12
The estimate for compound 4 lay 0.02 log units below the measured number; measured number inside the range.
By their numbers in this assay, from the lowest: compound 3; then compound 2; then compounds 4 and 1 (each within the scatter of the next).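

In this assay, among these compounds, the step of a number 0.03 log units lower from compound 1 to compound 4 (within the scatter) shows that exchanging 4-methylpyridin-2-yl for 6-methylpyridin-2-yl at this saturated chain carbon leaves no difference that can be read, a comparison the earlier compounds could not offer with only one methylpyridinyl group among them. The large step of a number 1.29 log units higher from compound 3 to compound 4 (beyond the scatter) shows that the wide separation from the pyridazin-3-yl compound is not confined to 4-methylpyridin-2-yl, and the modest step of a number 0.63 log units higher from compound 2 to compound 4 (beyond the scatter) puts the second methylpyridinyl compound on the same side of the hydrogen compound as compound 1, while compound 3 goes against this direction. No measurement supplied here accounts for these steps.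

Compound 3 and compound 4 differ at once in the methyl group and in the hetero atoms of the ring, so the compounds shown do not separate these two changes. A plain pyridin-2-yl group or a methyl-substituted pyridazin-3-yl group at the same carbon would bear on that question, and a 5-methylpyridin-2-yl group would test whether the methyl group's placement stays without a readable effect.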